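The compounds below may be only part of what the source reports. "The series", "measured", "known", "first", "only" and "open" are said of these compounds alone.

Compound 1, `Nc1ncnc2c1c(-c1cc(C3CC3)on1)nn2C1CCCCC1`, is the more potent of two measured compounds: in an assay on BaF3 cells for inhibition of proto-oncogene tyrosine-protein kinase receptor Ret (Homo sapiens), read by MTT assay, with a stated time of 48 h (on this read-out higher numbers stand for weaker inhibition of growth and lower numbers for stronger inhibition of growth), compound 1 gives 520 nM, while compound 2, `CC(C)n1nc(-c2cc(-c3ccccc3)on2)c2c(N)ncnc21`, gives 3460 nM, a gap that lies beyond the usual scatter. Compound 3, `Nc1ncnc2c1c(-c1cc(C3CC3)on1)nn2C1CCOCC1`, differs from compound 1 in one place: oxan-4-yl in place of cyclohexyl on an aromatic nitrogen. Among the measured compounds shown here, no measured pair in this set shows this kind of exchange, so the size of its effect is unknown; a step from compound 1 to compound 3 that stays within the scatter, or is at most slightly toward weaker inhibition, is expected, so that a 1.4-fold higher number from compound 1 to compound 3 (0.16 log units; within the scatter). Compound 3 is estimated to give 750 nM, within a range of 250 nM to 2200 nM.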

Compound 3, concentration for 50% growth inhibition: 440 nM
Compound 3: middle estimate off by 1.7-fold (0.23 log units), on the high side; measured number inside the range.
By their numbers in this assay, from the lowest: compounds 3 and 1 (each within the scatter of the next); then compound 2.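

Replacing cyclohexyl with oxan-4-yl on the aromatic nitrogen keeps the count at 6 heavy atoms but adds a ring oxygen and 1 hydrogen-bond acceptor, and gives a 1.2-fold lower number from compound 1 to compound 3 (0.07 log units; within the scatter) in this assay. The earlier compounds shown here offered no pair differing only here, and this pair now shows that the exchange leaves the number within the scatter. Nothing available explains why the two compounds read alike. Still open, going by these compounds, is how a ring bearing an amine, such as piperidin-4-yl, or one bearing a carboxylic acid would read at this position.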